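The compounds below may be only part of what the source reports. "The series", "measured", "known", "first", "only" and "open" are said of these compounds alone.

Compound 2 `COc1ccc(C2=NN(C3=NC(=O)/C(=C4\C(=O)Nc5ccccc54)S3)C(c3ccc(OC)cc3)C2)cc1` holds the higher of the two numbers recorded in a functional assay on cells (Cancer cell lines, Homo sapiens) for cytotoxicity, read by sulforhodamine B assay, with a stated time of 48 h; on this read-out lower numbers stand for stronger inhibition of growth and higher numbers for weaker inhibition of growth: compound 2 gives 91600 nM, while compound 1 `COc1ccc(C2CC(c3ccccc3)=NN2C2=NC(=O)/C(=C3\C(=O)Nc4ccccc43)S2)cc1` gives 6040 nM. For the measured compounds named here, the only step measured so far is a 15-fold higher number from compound 1 to compound 2 (1.18 log units; beyond the scatter). Compound 3 `COc1ccc(C2CC(c3ccc4ccccc4c3)=NN2C2=NC(=O)/C(=C3\C(=O)Nc4ccccc43)S2)cc1` differs from compound 2 by naphthalen-2-yl in place of 4-methoxyphenyl on a carbon with a double bond to nitrogen. Going by the values given here, the methoxy-bearing group leaves, and a lower number is therefore expected because a 15-fold higher number from compound 1 to compound 2 (1.18 log units; beyond the scatter) accompanied its arrival; the larger entering group has no measured precedent here. The step from compound 2 to compound 3 is estimated as a 10-fold lower number from compound 2 to compound 3 (1.01 log units; beyond the scatter). Compound 3 is estimated at 9000 nM, within 2000 nM to 40000 nM.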

Compound 3, concentration for total growth inhibition: 4030 nM
Compound 3: the middle estimate sits 2.2-fold (0.35 log units) above what was measured; low and high end bracket the measured number.
By their numbers in this assay, from the lowest: compounds 3 and 1 (each within the scatter of the next); then compound 2.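

At this carbon with a double bond to nitrogen, naphthalen-2-yl in place of 4-methoxyphenyl gives a 23-fold lower number from compound 2 to compound 3 (1.36 log units; beyond the scatter) and so shows that a group with more heavy atoms need not bring the high number. Naphthalen-2-yl in place of phenyl gives a 1.5-fold lower number from compound 1 to compound 3 (0.18 log units; within the scatter) and so leaves compound 1 and compound 3 indistinguishable, with one aromatic ring or two at this place. No measurement here explains why 4-methoxyphenyl stands apart. Open, on these data alone, is whether a chlorine or a dimethylamino group in the methoxy's place on that phenyl would also give a high number.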